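Extending the chain of compound 1 with a thioether

The source may hold more compounds than are shown below. What is called first, only, known or untested is meant among the compounds shown, and "the series" means these compounds.

Among the measured compounds shown here, compound 1 `Cc1cc(N)nc(CC(C)C)c1` gives 193 nM in an assay on isolated protein for inhibition of Nitric oxide synthase, inducible (Homo sapiens), with a stated time of 30 min (on this read-out lower numbers stand for stronger inhibition and higher numbers for weaker inhibition), the lowest of the two numbers measured so far. Compound 2 `Cc1cc(N)nc(CC(C)F)c1` gives 220 nM in this assay. For the measured compounds named here, the step of a 1.1-fold higher number from compound 1 to compound 2 (0.06 log units; within the scatter) is the only comparison available and lay within the scatter. Compound 3 `CSCCC(C)Cc1cc(C)cc(N)n1` carries (methylsulfanyl)methyl in place of hydrogen on a saturated chain carbon, three bonds along the chain from an aromatic carbon. Going by the values given here, since the single measured step left the number essentially unchanged, the change to compound 3 is expected to bring at most a small step, if any, beyond the scatter. Compound 3 is therefore estimated at 250 nM, within 80 nM to 800 nM, which would mean a 1.3-fold higher number from compound 1 to compound 3 (0.11 log units; within the scatter).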

Compound 3, half-maximal inhibitory concentration: > 5000 nM
Compound 3: a limit, no number; the forecaster's own chance of this, stated with the estimate: 5%; at least 20-fold (1.30 log units) between middle value and limit.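

In this assay compound 3 stands at a limit of the assay and not at a number: the limit of > 5000 nM in this assay, at which 1 of the 3 values shown sits. The steps read an at least 25-fold higher number from compound 1 to compound 3 (1.41 log units; beyond the scatter) and an at least 22-fold higher number from compound 2 to compound 3 (1.35 log units; beyond the scatter). Among the compounds shown here, the swap of methyl for fluoro had stayed within the scatter, so only this change shows that the number is sensitive at this chain carbon, and that adding (methylsulfanyl)methyl there is not tolerated as the smaller change was. The compounds shown leave open whether the sulfur or the added length alone accounts for this. A plain longer chain, an ether oxygen in place of the sulfur, or a terminal amine could separate these.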